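Nitro in Place of Chloro on Compound 3

This account rests on a few compounds, and the source may have more. Where it says the series, first, only, none or still open, it means among the compounds named here.

In an ADME assay on MT4 cells (Homo sapiens) for cytotoxicity, read by MTT assay (a higher number here means that more compound is tolerated, a lower number that less compound is tolerated), compound 1 `Cc1ccc(C(=O)N(C(=S)OCCN2C(=O)c3ccccc3C2=O)c2ccc(Cl)cc2)cc1` reads > 100000 nM, which is a limit of the assay and not a number. Compound 3 `O=C1c2ccccc2C(=O)N1CCOC(=S)N(C(=O)c1ccc(Cl)c(Cl)c1)c1ccc(Cl)cc1` gives 35000 nM, level with compound 2 `O=C1c2ccccc2C(=O)N1CCOC(=S)N(C(=O)c1c(F)cccc1F)c1ccc(Cl)cc1` at 39000 nM. Both lie under compound 1: an at least 2.5-fold lower number from compound 1 to compound 2 (0.40 log units; beyond the scatter) and an at least 2.8-fold lower number from compound 1 to compound 3 (0.45 log units; beyond the scatter). Compound 4 `O=C1c2ccccc2C(=O)N1CCOC(=S)N(C(=O)c1ccc(Cl)c([N+](=O)[O-])c1)c1ccc(Cl)cc1` carries nitro in place of chloro on an aromatic carbon, ortho to a chloro group (nitro in place of chloro on an aromatic carbon). The closest guide is the swap of the group on the carbonyl carbon between compound 2 and compound 3, a 1.1-fold lower number from compound 2 to compound 3 (0.05 log units; within the scatter). On that basis, the expected result is no change beyond the scatter, a 1.2-fold lower number from compound 3 to compound 4 (0.07 log units; within the scatter). Compound 4 is estimated at 30000 nM, with an expected range of 12000 nM to 80000 nM.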

Compound 4, half-maximal cytotoxic concentration: 48000 nM
The estimate for compound 4 lay 1.6-fold (0.20 log units) below the measured number; the measured number falls inside the stated range.
By their numbers in this assay, from the lowest: compounds 3, 2 and 4 (each within the scatter of the next). At a limit, above all of these: compound 1.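

In this assay, nitro in place of chloro on this aromatic carbon, ortho to a chloro group, gives no change that can be read (a 1.4-fold higher number from compound 3 to compound 4 (0.14 log units; within the scatter)), so the larger group leaves the number where it was. The new 4-chloro-3-nitrophenyl group also stays level with 2,6-difluorophenyl (a 1.2-fold higher number from compound 2 to compound 4 (0.09 log units; within the scatter)). Like the other two groups, it stands under 4-methylphenyl (an at least 2.0-fold lower number from compound 1 to compound 4 (0.31 log units; beyond the scatter)), a comparison that rests on a limit and not on a number: the limit of > 100000 nM in this assay, at which 1 of the 4 values shown sits.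

As far as these compounds go, whether an amine or a carboxylic acid on this carbon would move the number beyond the scatter remains open. So does the effect of replacing the remaining chloro group.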